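Amide nitrogen substituent: allyl to isopropyl in the series

A few compounds are considered here, and "the series" means these few. Any claim that something is new, unique, unknown or untested is made for them only; others in the source may bear on it.

Compound 3 `C=CCNC(=O)c1cc(OCCCC)n(-c2ccccc2)n1` gives 4.4% in a functional assay on the whole organism (strain Wistar) for inhibition, with Rattus norvegicus as the target, read by paw edema, with stated times of 30 min and 3 h, at a dose of 100 mg/kg by the oral route (on this read-out lower numbers stand for less inhibition and higher numbers for more inhibition at the one dose given (going by the name of the read-out)), and stands lowest of the three measured compounds. Compound 1 `CNC(=O)c1cc(OC)n(-c2ccccc2)n1` gives 57.9% and compound 2 `CCCCOc1cc(C(=O)NC)nn1-c1ccccc1` gives 65%; the step of a number 7.1 percentage points higher from compound 1 to compound 2 (within the scatter) lies within the scatter, whereas the step of a number 60.6 percentage points lower from compound 2 to compound 3 (beyond the scatter) is large and beyond it.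

Compound 4 `CCCCOc1cc(C(=O)NC(C)C)nn1-c1ccccc1` differs from compound 3 by isopropyl in place of allyl on an amide-type nitrogen. Within the data shown here, the only measured step touching the same position is a number 60.6 percentage points lower from compound 2 to compound 3 (beyond the scatter), which compares hydrogen with vinyl on the chain carbon bound to the amide nitrogen. Among the measured compounds shown here, it does not compare two three-carbon groups at that nitrogen, so no measured pair bears directly on the exchange of allyl for isopropyl. Both compound 3 and compound 4 carry a three-carbon group there, and compound 3 shows that such a group can remove most of the inhibition.

The expectation is therefore that compound 4 stays in the low range, with any change from compound 3 expected to be a number 10.6 percentage points higher from compound 3 to compound 4 (beyond the scatter), not clearly beyond the scatter. For compound 4 the estimate is 15%, with a range from 0% to 42%.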

Compound 4, a percentage reported as inhibition, in the whole organism at one dose (the size of the read-out at that dose, not a potency): 15.8%
Compound 4: the middle estimate sits 0.8 percentage points below what was measured; the measured number falls inside the stated range.
By their numbers in this assay, from the lowest: compound 3; then compound 4; then compounds 1 and 2 (each within the scatter of the next).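

In this assay the exchange on the amide-type nitrogen gives a number 11.4 percentage points higher from compound 3 to compound 4 (beyond the scatter) and shows that the two three-carbon groups can be told apart at this position, although both remain low. The second step, a number 49.2 percentage points lower from compound 2 to compound 4 (beyond the scatter), shows that the large loss seen with allyl also occurs with isopropyl, so it does not require the double bond of allyl. Nothing available explains either step.

The compounds shown leave open how the number runs with an ethyl or straight propyl group on this nitrogen, or with a cyclopropyl ring there. They also leave open whether isopropyl or allyl on the amide nitrogen costs as much when methoxy replaces the butoxy chain, as in the core of compound 1.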